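A few compounds are considered here, and "the series" means these few. Any claim that something is new, unique, unknown or untested is made for them only; others in the source may bear on it.

Series notes. Among the compounds with values here, compound 1 `O=C(O)CN1C(=O)/C(=C/c2nc3ccccc3n2Cc2ccccc2)SC1=S` gives 22700 nM in a functional assay on HeLa cells (Homo sapiens) for cytotoxicity, read by MTT assay, with a stated time of 48 h (a lower number here means a stronger inhibitor, a higher number a weaker inhibitor), and stands highest of the three numbers measured so far. Compound 2 `O=C(O)CN1C(=O)/C(=C/c2nc3ccccc3n2Cc2ccc(C(F)(F)F)cc2)SC1=S` gives 21400 nM in this assay, and compound 3 `O=C(O)CN1C(=O)/C(=C/c2nc3ccccc3n2Cc2ccccc2F)SC1=S` gives 640 nM in this assay. The two steps from compound 1 differ sharply in size: a 1.1-fold lower number from compound 1 to compound 2 (0.03 log units; within the scatter), whereas a 35-fold lower number from compound 1 to compound 3 (1.55 log units; beyond the scatter); between the substituted analogues, a 33-fold lower number from compound 2 to compound 3 (1.52 log units; beyond the scatter).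

Compound 4 `COc1cc(Cn2c(/C=C3\SC(=S)N(CC(=O)O)C3=O)nc3ccccc32)cc(OC)c1` is not yet measured. It differs from compound 1 in one place: 3,5-dimethoxyphenyl in place of phenyl on a saturated chain carbon bound to an aromatic nitrogen. Within the data shown here, no measured step puts methoxy groups on this ring, so the two steps from compound 1 bear on it only loosely. The trifluoromethyl step left the number within the scatter, while the fluoro step was large; a substitution of a different kind is as likely to fall near the first as near the second. A modest change, if any, is expected, with a 1.5-fold lower number from compound 1 to compound 4 (0.18 log units; within the scatter) taken as the working assumption. Compound 4 is therefore estimated at 15000 nM in this assay, within a range of 4500 nM to 45000 nM.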

Compound 4, half-maximal inhibitory concentration: 17700 nM
The estimate for compound 4 lay 1.2-fold (0.07 log units) below the measured number; measured number inside the range.
By their numbers in this assay, from the lowest: compound 3; then compounds 4, 2 and 1 (each within the scatter of the next).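

In this assay, within the data shown here, the 3,5-dimethoxyphenyl group brings oxygen onto this ring for the first time, yet compound 4 cannot be told apart from the unsubstituted phenyl of compound 1 (a 1.3-fold lower number from compound 1 to compound 4 (0.11 log units; within the scatter)) or from the 4-(trifluoromethyl)phenyl of compound 2 (a 1.2-fold lower number from compound 2 to compound 4 (0.08 log units; within the scatter)). The gap to the 2-fluorophenyl group remains large (a 28-fold higher number from compound 3 to compound 4 (1.44 log units; beyond the scatter)), so compound 3 stands alone while compounds 1, 2 and 4 form one group within the scatter. Substitution on this ring therefore does not by itself give the low number, as compounds 2 and 4 both go against such a reading.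

From the compounds shown here alone, whether a 2-chlorophenyl or a 4-fluorophenyl group would follow compound 3 or compound 4 remains open. Nothing at hand explains why compound 3 stands apart.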